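A few compounds are considered here, and "the series" means these few. Any claim that something is new, unique, unknown or untested is made for them only; others in the source may bear on it.

Compound 1 `CC(=O)N[C@@H](CSC/C=C(\C)CC/C=C(\C)CCC=C(C)C)C(=O)C=[N+]=[N-]` is the point of departure. In a functional assay on MOLT-3 cells (Homo sapiens) (a lower number here means a stronger inhibitor, a higher number a weaker inhibitor), compound 1 gives 32200 nM. Compound 2 `CC(C)=CCC/C(C)=C/CC/C(C)=C/CSC[C@H](NC(=O)OC(C)(C)C)C(=O)C=[N+]=[N-]` differs from it in one place, tert-butoxy in place of methyl on a carbonyl carbon; in this assay compound 2 gives 50100 nM, and the step of a 1.6-fold higher number from compound 1 to compound 2 (0.19 log units; within the scatter) leaves the two numbers within the scatter of each other, so neither compound can be set above the other.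

Compound 3 `CC(=O)N[C@@H](CSC/C=C(\C)CCC=C(C)C)C(=O)C=[N+]=[N-]` has not been measured. It differs from compound 1 by hydrogen in place of 3-methylbut-2-en-1-yl on a saturated chain carbon bound to a double-bonded chain carbon; the change sits on the thioether chain, not at the carbonyl carbon that the step from compound 1 to compound 2 concerns. Among the measured compounds shown here, no measured step touches the chain, so the only bearing step is uninformative here. The expectation is a rise in the number, of uncertain size, for the chain shortened by one 3-methylbut-2-en-1-yl unit: the step of a 2.0-fold higher number from compound 1 to compound 3 (0.31 log units; beyond the scatter) is estimated, and compound 3 is expected to give 65000 nM in this assay, within 20000 nM to 200000 nM.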

Compound 3, half-maximal inhibitory concentration: > 100000 nM
Compound 3 gave a limit, no number; the forecaster's own chance of this, stated with the estimate: 30%; at least 1.5-fold (0.18 log units) between middle value and limit.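

Among the compounds shown here, the thioether chain is the first place where a single change moves the number beyond the scatter: hydrogen in place of 3-methylbut-2-en-1-yl on a saturated chain carbon bound to a double-bonded chain carbon gives an at least 3.1-fold higher number from compound 1 to compound 3 (0.49 log units; beyond the scatter) in this assay. The change at the carbonyl carbon, by contrast, stays within the scatter, with a 1.6-fold higher number from compound 1 to compound 2 (0.19 log units; within the scatter) as its step. Compound 3 gives a limit and not a number, so its step has a lower bound only: the limit of > 100000 nM in this assay, at which 1 of the 3 values shown sits.

On these data alone, whether a longer chain, with one more 3-methylbut-2-en-1-yl unit than compound 1 carries, would lower the number remains open. Also open, as far as these compounds go, is how a carboxylic acid at the chain end would read in this assay.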